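The source may report more compounds than this note shows. Statements on the series, on what has been measured and on what is new or still open speak of the compounds shown alone.

Measured so far in a functional assay on HL-60 cells (Homo sapiens) for cytotoxicity, read by WST assay, with a stated time of 48 h; on this read-out lower numbers stand for stronger inhibition and higher numbers for weaker inhibition:
compound 1, `Cc1ccc(/C=C/C[C@H]2C[C@@H]([C@@H](O)c3ccccc3)CO[C@@H]2c2ccccc2)cc1C`, gives 9880 nM
compound 2, `COc1ccc(/C=C/C[C@H]2C[C@@H]([C@@H](O)c3ccccc3)CO[C@@H]2c2ccccc2)cc1`, gives 9010 nM
compound 3, `Oc1cccc(/C=C/C[C@H]2C[C@@H]([C@@H](O)c3ccccc3)CO[C@@H]2c2ccccc2)c1`, gives 12800 nM

Compound 3 holds the highest of the three numbers, but its gaps to compound 1 and to compound 2 both lie within the scatter, so no order among the three can be read. Compound 4, `COc1ccccc1/C=C/C[C@H]1C[C@@H]([C@@H](O)c2ccccc2)CO[C@@H]1c1ccccc1`, carries 2-methoxyphenyl in place of 3-hydroxyphenyl on a double-bonded chain carbon bound to a double-bonded chain carbon. Among the compounds with values here, the steps that bear on this change are the earlier swaps of the ring on the double-bonded chain carbon: a 1.3-fold higher number from compound 1 to compound 3 (0.11 log units; within the scatter), a 1.4-fold higher number from compound 2 to compound 3 (0.15 log units; within the scatter) and a 1.1-fold lower number from compound 1 to compound 2 (0.04 log units; within the scatter), none of them beyond the scatter. Three different rings at that place left no step beyond the scatter, so for compound 4 no step beyond the scatter is expected either: a 1.2-fold lower number from compound 3 to compound 4 (0.09 log units; within the scatter). Compound 4 is estimated at 10500 nM, with a range from 5000 nM to 22000 nM.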

Compound 4, half-maximal inhibitory concentration: 10100 nM
For compound 4 the middle estimate is 1.0-fold (0.02 log units) above the measured one; the range from low to high includes it.
By their numbers in this assay, from the lowest: compounds 2, 1, 4 and 3 (each within the scatter of the next).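

In this assay, 2-methoxyphenyl in place of 3-hydroxyphenyl on a double-bonded chain carbon removes the hydrogen-bond donor counted on the leaving group and gives a 1.3-fold lower number from compound 3 to compound 4 (0.10 log units; within the scatter) as its step. Against the other two rings the readings are a 1.1-fold higher number from compound 2 to compound 4 (0.05 log units; within the scatter) and a 1.0-fold higher number from compound 1 to compound 4 (0.01 log units; within the scatter) so four different substituted phenyl groups at this place cannot be told apart on this read-out. No supporting data bear on why the numbers stay so close.

Open, going by these compounds, is whether an amine or a carboxylic acid on this phenyl ring would give a step beyond the scatter.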